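Adding a Fluoro to the Aromatic Ring of Compound 1

The source may hold more compounds than are shown below. What is called first, only, known or untested is meant among the compounds shown, and "the series" means these compounds.

Measured compounds:
Compound 1, `COc1ccc(CN([C@@H]2CC(F)(F)CCNC2=O)S(=O)(=O)c2ccc(Cl)cc2)c(F)c1`, gives in an in vitro ADME assay on microsomes from liver (Mus musculus) for pharmacokinetics (on this read-out higher numbers stand for fast clearance and lower numbers for slow clearance), a value of 105 mL.min-1.g-1.
Compound 2, `O=C(NC1CC1)c1ccc(CN(C2CC(C(F)(F)F)CCNC2=O)S(=O)(=O)c2ccc(Cl)cc2)cc1`, gives 39 mL.min-1.g-1.
Compound 3, `CC1(C)CCNC(=O)C(N(Cc2ccc(C(=O)NC3CC3)cc2)S(=O)(=O)c2ccc(Cl)cc2)C1`, gives 191 mL.min-1.g-1.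

Compound 1 stands second highest of the three numbers. Its nearest neighbour is compound 3, whose number is higher by an amount that lies within the scatter of this assay, so the two are not told apart. Its furthest neighbour is compound 2, whose lower number lies beyond the scatter.

The unmeasured compound 4, `COc1ccc(CN([C@@H]2CC(F)(F)CCNC2=O)S(=O)(=O)c2ccc(Cl)cc2)c(F)c1F`, differs from compound 1 in one place: fluoro in place of hydrogen on an aromatic carbon. The fluoro enters ortho to a fluoro group and ortho to a methoxy group, and meta to a large group.

For the measured compounds named here, the only step measured between two compounds, a 4.9-fold higher number from compound 2 to compound 3 (0.69 log units; beyond the scatter), concerns the group on the sulfonamide nitrogen and not the aromatic ring, so it does not bear on this change. Going by the values given here, no measured pair shows the effect of a fluoro entering an aromatic carbon. The expectation for compound 4 therefore rests on compound 1 alone, and the change is expected to give a step of a 1.2-fold lower number from compound 1 to compound 4 (0.07 log units; within the scatter), which is not beyond the scatter.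

Compound 4 is estimated at 90 mL.min-1.g-1, with a range from 45 mL.min-1.g-1 to 180 mL.min-1.g-1.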

Compound 4, intrinsic clearance in microsomes: 121 mL.min-1.g-1
Compound 4: the middle estimate sits 1.3-fold (0.13 log units) below what was measured; low and high end bracket the measured number.
By their numbers in this assay, from the lowest: compound 2; then compounds 1, 4 and 3 (each within the scatter of the next).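

In this assay, for the compounds shown here, the fluoro entering on the aromatic carbon gives a 1.2-fold higher number from compound 1 to compound 4 (0.06 log units; within the scatter) and this is the first measured pair that speaks to a change on this aromatic ring. On this read-out the 2-fluoro-4-methoxyphenyl and 2,3-difluoro-4-methoxyphenyl groups are not told apart, so this carbon, ortho to a fluoro group and ortho to a methoxy group, takes a fluoro without a step beyond the scatter. No supporting data bear on why the number holds at this position.

The compounds shown leave open whether another group on this same aromatic carbon, such as a chloro, a methyl, a nitrile, an amine or a carboxylic acid, would also stay within the scatter of compound 1 or would move the number beyond it. They also leave open whether a fluoro entering here would give a similar step on a compound other than compound 1, or whether replacing the methoxy group, for instance with an ethoxy group, would matter more than adding a fluoro.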